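Trading a methylamino chain for allyl on sulfur

A few compounds are considered here, and "the series" means these few. Any claim that something is new, unique, unknown or untested is made for them only; others in the source may bear on it.

Measured in a functional assay on HT cells (Homo sapiens) for antiproliferative activity, read by fluorescence, with a stated time of 72 h; on this read-out higher numbers stand for weaker inhibition of growth and lower numbers for stronger inhibition of growth:
compound 1 `CC(C)c1n[nH]c2c(NCc3ccc(-c4ccccn4)cc3)nc(SCCO)nc12`: 48 nM
compound 2 `CC(C)c1n[nH]c2c(NCc3ccc(-c4ccccn4)cc3)nc(SC(C)C(C)O)nc12`: 190 nM
compound 3 `CNCCSc1nc(NCc2ccc(-c3ccccn3)cc2)c2[nH]nc(C(C)C)c2n1`: 56 nM

Compound 3 matches one neighbour, a 1.2-fold higher number from compound 1 to compound 3 (0.07 log units; within the scatter), and parts from the other, a 3.4-fold lower number from compound 2 to compound 3 (0.53 log units; beyond the scatter). Compound 4 `C=CCSc1nc(NCc2ccc(-c3ccccn3)cc2)c2[nH]nc(C(C)C)c2n1` carries vinyl in place of (methylamino)methyl on a saturated chain carbon bound to a sulfur, which amounts to 2-(methylamino)ethyl to allyl. Within the data shown here, two measured steps bear on this. Changing the chain end gave a 1.2-fold higher number from compound 1 to compound 3 (0.07 log units; within the scatter), while the 2-hydroxy-1-methylpropyl chain gave a 4.0-fold higher number from compound 1 to compound 2 (0.60 log units; beyond the scatter). Among the measured compounds shown here, no measured compound carries allyl, so the guide is indirect. The expected change is small, a 1.3-fold higher number from compound 3 to compound 4 (0.10 log units; within the scatter). Compound 4 is estimated at 70 nM, with an expected range of 30 nM to 170 nM.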

Compound 4, concentration for 50% growth inhibition: 1010 nM
Compound 4: the middle estimate sits 14-fold (1.16 log units) below what was measured; measured number above the stated range.
By their numbers in this assay, from the lowest: compounds 1 and 3 (each within the scatter of the next); then compound 2; then compound 4.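

Replacing the end of the chain on sulfur had mattered little between hydroxy and methylamino, but allyl, which has neither group, costs far more growth inhibition (an 18-fold higher number from compound 3 to compound 4 (1.26 log units; beyond the scatter); a 21-fold higher number from compound 1 to compound 4 (1.32 log units; beyond the scatter)). Both steps are large, so this position does not tolerate every small chain. Even compound 2, the weakest of the earlier three, stays ahead of allyl (a 5.3-fold higher number from compound 2 to compound 4 (0.73 log units; beyond the scatter)).

Going by these compounds, whether the loss comes with the missing hydroxy or amine or with the double bond stays open, as a saturated propyl chain or a longer chain ending in an amine could separate the two. No measured evidence here accounts for the loss.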